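Methoxy for Methyl: Expected Permeability of Compound 4

The source may hold more compounds than are shown below. What is called first, only, known or untested is meant among the compounds shown, and "the series" means these compounds.

Of the compounds shown here, three have been measured in an ADME assay for permeability, using PAMPA, with a stated time of 18 h, tested at 25 ug/mL; on this read-out higher numbers stand for higher permeability and lower numbers for lower permeability. Compound 1 `Cc1ccc(CNS(=O)(=O)/C=C/c2ccc(O)c(O)c2)cc1` gives 6.7 10^-6 cm/s. Among the measured compounds shown here, compound 2 `COc1ccc(CNS(=O)(=O)/C=C/c2ccc(O)c(O)c2)cc1` gives 4.7 10^-6 cm/s; the single change between the two is methoxy in place of methyl on an aromatic carbon, and the step is a 1.4-fold lower number from compound 1 to compound 2 (0.15 log units; within the scatter). Compound 3 `CC(=O)Oc1ccc(/C=C/S(=O)(=O)NCc2ccc(C)cc2)cc1OC(C)=O` gives 8.6 10^-6 cm/s; its distances to compound 1 and to compound 2 both lie within the scatter. The difference between the core of compound 3 and the core of compound 1 is not broken down here.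

Compound 4 `COc1ccc(CNS(=O)(=O)/C=C/c2ccc(OC(C)=O)c(OC(C)=O)c2)cc1` has not yet been measured. It differs from compound 3 by methoxy in place of methyl on an aromatic carbon, the same kind of change as that from compound 1 to compound 2, and the place reads the same for both. Because that change earlier gave a 1.4-fold lower number from compound 1 to compound 2 (0.15 log units; within the scatter), the step expected in this assay for compound 4 is a 1.4-fold lower number from compound 3 to compound 4 (0.14 log units; within the scatter). The estimate for compound 4 in this assay is 6.2 10^-6 cm/s, expected to fall between 3.5 10^-6 cm/s and 10.5 10^-6 cm/s.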

Compound 4, apparent permeability: 11.6 10^-6 cm/s
Compound 4: the middle estimate sits 1.9-fold (0.27 log units) below what was measured; the measured number lies above the stated range.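

In this assay, the change from 4-methylbenzyl to 4-methoxybenzyl on the core of compound 3 gives a 1.3-fold higher number from compound 3 to compound 4 (0.13 log units; within the scatter). Set beside the same change on the core of compound 1, this step cannot be told apart from the earlier one: the same change on two cores in this assay, a 1.4-fold lower number (0.15 log units; within the scatter) from compound 1 to compound 2 and a 1.3-fold higher number (0.13 log units; within the scatter) from compound 3 to compound 4, 1.9-fold (0.28 log units) apart, within the scatter of two such steps. The two pairs therefore show that the change carried from one core to the other without a step, or a gap between steps, that stands clear of the scatter; they do not show that methoxy and methyl differ on this read-out, nor that the two cores answer to the change in different ways, and each step rests on a single pair of compounds.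

The compounds shown leave open whether another group at this place, such as an amine, a carboxylic acid or a longer chain like ethoxy, would give a step beyond the scatter. They also leave open how the change would read on any core other than these two.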